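The compounds below may be only part of what the source reports. "The series", "measured", "known", "first", "only" and "open" are said of these compounds alone.

Three compounds share one core: a six-membered saturated ring with one nitrogen carries an aromatic group on a ring carbon, and a short linker ties that ring to an amide. In a functional assay on HEK293 cells for agonist activity at D(4) dopamine receptor (Homo sapiens), read by FLIPR (a higher number here means a larger maximal response, a lower number a smaller maximal response), compound 1 `Cc1cc(NC(=O)CN2CCC(c3cccc[n+]3[O-])CC2)ccc1F` gives 75%. In this assay compound 2 `Cc1cccc(NC(=O)CN2CCC(c3ccc(O)cc3)CC2)c1` gives 60%, and compound 3 `N#Cc1cccc(C(=O)NCN2CCC(c3cccc[n+]3[O-])CC2)c1` gives 69%. On the numbers shown compound 2 stands lowest, yet its gap to compound 3 lies within the usual scatter and so does not rank the two, while its gap to compound 1 lies beyond the scatter.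

Compound 4 `Cc1cccc(NC(=O)CN2CCC(c3ccccc3F)CC2)c1` has not been measured. It differs from compound 2 in one place: 2-fluorophenyl in place of 4-hydroxyphenyl on a saturated ring carbon. Among the measured compounds shown here, no measured pair differs in exactly this way, so the size of the step is uncertain. Compound 1 and compound 3 both carry another aromatic group on that same carbon and both sit above compound 2, which sets the range in which a guess is framed. For compound 4 a modest rise, a number 8 percentage points higher from compound 2 to compound 4 (within the scatter), is expected, though a step within the scatter would not surprise. Compound 4 is estimated at 68% in this assay, with a likely range from 52% to 84%.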

Compound 4, largest response reached (reported as efficacy), in percent of the reference or control that the assay uses: 57%
Compound 4: the middle estimate sits 11 percentage points above what was measured; measured number inside the range.
By their numbers in this assay, from the lowest: compounds 4, 2, 3 and 1 (each within the scatter of the next, the first and the last beyond it).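

In this assay, putting 2-fluorophenyl in place of 4-hydroxyphenyl on the saturated ring carbon gives a number 3 percentage points lower from compound 2 to compound 4 (within the scatter), so this pair cannot be told apart by maximal response. Among the compounds shown here, this is the first direct comparison at this position, and it shows that the response holds when a group with 1 hydrogen-bond donor and 1 hydrogen-bond acceptor gives way to one with 0 of each, at least for this single pair. Nothing shown here explains why the response holds.

Because the change removes the hydroxy group and adds a fluorine in one step, this pair cannot separate the two, and an unsubstituted phenyl group on the same carbon would be needed to show what each contributes alone. On these data alone, it also remains open whether the same carbon would hold the response with a phenyl ring bearing an amine or a carboxylic acid, which would test the position with groups unlike either of these two.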